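Mirror-image change at the chain stereocentre of compound 3

This account rests on a few compounds, and the source may have more. Where it says the series, first, only, none or still open, it means among the compounds named here.

Compound 3 `Cc1cc(Cl)ccc1NC(=O)[C@H](C)N` gives 41.3 mg/kg in a functional assay on the whole organism (strain Swiss Albino) with Mus musculus as the target; on this read-out higher numbers stand for an effect only at larger amounts of compound and lower numbers for an effect already at smaller amounts. Among the measured compounds shown here, of the three compounds measured so far, this is the highest number: compound 1 `Cc1cc(Cl)cc(C)c1NC(=O)[C@H](C)N` gives 25.5 mg/kg in this assay, and compound 2 `Cc1cc(Cl)cc(C)c1NC(=O)[C@@H](C)N` gives 17.8 mg/kg. The gap between compound 3 and compound 1 stays within the scatter, whereas the gap between compound 3 and compound 2 goes beyond it.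

Compound 4 `Cc1cc(Cl)ccc1NC(=O)[C@@H](C)N` differs from compound 3 in one respect only: the two compounds have the same atoms and bonds and differ only in configuration as drawn: 1 of 1 stereo elements differ; a stereocentre at a saturated chain carbon is drawn S in compound 3 and R in compound 4. The same kind of change has been measured once already, between compound 1 and compound 2, where a 1.4-fold lower number from compound 1 to compound 2 (0.16 log units; within the scatter); that comparison rests on (the fact that compounds 1 and 2 differ only in the configuration as drawn). The other measured step, a 1.6-fold higher number from compound 1 to compound 3 (0.21 log units; within the scatter), concerns a methyl group and does not bear directly on a change of configuration.

On this basis no shift beyond the scatter is expected in this assay for compound 4; if anything, a slightly lower number in the direction seen in a 1.4-fold lower number from compound 1 to compound 2 (0.16 log units; within the scatter) is anticipated. Compound 4 is therefore estimated at 30 mg/kg, with a range from 15 mg/kg to 60 mg/kg, which means an expected step of a 1.4-fold lower number from compound 3 to compound 4 (0.14 log units; within the scatter).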

Compound 4, dose for half-maximal effect: 39.2 mg/kg
Beside the measured number, compound 4's estimate is 1.3-fold (0.12 log units) below it, and the stated range covers the measured number.
By their numbers in this assay, from the lowest: compounds 2, 1, 4 and 3 (each within the scatter of the next, the first and the last beyond it).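

On the core with hydrogen in place of methyl on the aromatic carbon, the change of configuration at the saturated chain carbon gives a 1.1-fold lower number from compound 3 to compound 4 (0.02 log units; within the scatter) in this assay. The stereocentre has now been inverted on two cores, and on neither does the number in this assay move beyond the scatter, a reading that is clean on this second core for one reason: the fact that compounds 3 and 4 differ only in the configuration as drawn. Among the compounds shown here, the new pair also gives the first hydrogen-for-methyl step beyond the scatter, a 2.2-fold higher number from compound 2 to compound 4 (0.34 log units; beyond the scatter), and this step agrees with the smaller one on the other core, so the methyl group on the aromatic carbon appears to count for about the same with either configuration: the same change on two cores in this assay, a 1.6-fold higher number (0.21 log units; within the scatter) from compound 1 to compound 3 and a 2.2-fold higher number (0.34 log units; beyond the scatter) from compound 2 to compound 4, 1.4-fold (0.13 log units) apart, within the scatter of two such steps.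

The compounds shown leave open whether the configuration stays without a readable effect when the methyl group on the stereocentre gives way to a longer chain such as isopropyl or benzyl, or when the primary amine becomes a dimethylamine. They also leave open how an ethyl or a methoxy group on that aromatic carbon would compare with methyl and hydrogen.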